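The compounds below may be only part of what the source reports. "The series", "measured", "known", "first", "only" and "open" are said of these compounds alone.

Measured compounds in a functional assay on the whole organism (Tail, strain ICR) with Mus musculus as the target, in the tail flick test, with a stated time of 150 min, at a dose of 25 umol/kg by the oral route; on this read-out higher numbers stand for a stronger effect at the one dose given and lower numbers for a weaker effect:
- compound 1, `O=C(CN(c1ncnc2c1ncn2C1CCCCO1)C1CC1)N[C@@H](CO)C(=O)OCc1ccccc1`: 18.3%
- compound 2, `CSCC[C@H](NC(=O)CN(c1nc(Cl)nc2[nH]cnc12)C1CC1)C(=O)OCc1ccccc1`: 17.6%
- compound 3, `NC(=O)CC[C@H](NC(=O)CN(c1ncnc2c1ncn2C1CCCCO1)C1CC1)C(=O)OCc1ccccc1`: 10.7%

All three values lie within the usual scatter of one another. Compound 2 sits between the other two on the numbers, with compound 1 a little above it and compound 3 a little below, neither gap beyond the scatter.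

Compound 4, `O=C(CN(c1nc(Cl)nc2[nH]cnc12)C1CC1)NCC(=O)OCc1ccccc1`, is not yet measured. It differs from compound 2 in one place: hydrogen in place of 2-(methylsulfanyl)ethyl on a saturated chain carbon bound to an amide-type nitrogen and a carbonyl carbon. Going by the values given here, the only measured step touching the same region of the molecule is the one between compound 1 and compound 3, where a different side chain was swapped at a nearby position and gave a number 7.6 percentage points lower from compound 1 to compound 3 (within the scatter). Among the compounds with values here, that step suggests changes in this part of the series move the read-out little, though removing the whole side chain is a larger change than any measured so far and no pair in the data tests it directly.

On this basis, for compound 4 the expected step is a number 2.6 percentage points lower from compound 2 to compound 4 (within the scatter), that is, none beyond the scatter. Compound 4 is estimated at 15%, with a range of 5% to 25% in this assay.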

Compound 4, a percentage reported as activity, at one dose (the size of the read-out at that dose, not a potency): 18%
The estimate for compound 4 lay 3 percentage points below the measured number; the range from low to high includes it.
By their numbers in this assay, from the lowest: compounds 3, 2, 4 and 1 (each within the scatter of the next).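

In this assay, hydrogen in place of 2-(methylsulfanyl)ethyl on the saturated chain carbon bound to an amide-type nitrogen and a carbonyl carbon gives a number 0.4 percentage points higher from compound 2 to compound 4 (within the scatter). The earlier compounds shown here only exchanged one side chain for another, whereas this pair tests the complete absence of a side chain at this carbon, and in this pair the read-out at the one dose given does not depend on 2-(methylsulfanyl)ethyl. No measured evidence on the compounds bears on this result.

Still open, on these data alone, is whether a side chain ending in an amine or a carboxylic acid at this carbon would give a value beyond the scatter of those seen so far. Also open, as far as these compounds go, is whether the same exchange for hydrogen gives a similar step on the core of compound 1.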